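Swapping a fluoro for a methyl on the aryl ring

The compounds below may be only part of what the source reports. "The series", "measured", "known", "first", "only" and "open" are said of these compounds alone.

Compound 2 `Cc1c(C#N)c(-c2ccccc2)nn1CCCN1CCN(c2ccc(F)cc2)CC1` holds the higher of the two numbers measured here. In a functional assay on the whole organism (Abdomen, strain Swiss) for inhibition, with Mus musculus as the target, with stated times of 30 min, 10 min and 5 min, at a dose of 40 mg/kg by the oral route (a higher number here means a stronger effect of the compound at the dose given, a lower number a weaker effect), compound 2 gives 51%. Among the compounds with values here, the only other measured compound, compound 1 `C=Cc1c(C)nn(CCCN2CCCN(c3ccc(C)cc3)CC2)c(=O)c1N`, differs from compound 2 in several places at once, so no single step links them; in this assay compound 1 gives 31%, a result that sits below that of compound 2 by a margin beyond the usual scatter.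

Compound 3 `Cc1ccc(N2CCN(CCCn3nc(-c4ccccc4)c(C#N)c3C)CC2)cc1` has not yet been measured. It differs from compound 2 by a single change: methyl in place of fluoro on an aromatic carbon. Within the data shown here, no measured pair shows this exchange of methyl for fluoro, so nothing among the measured compounds tells how large such a step tends to be. The change is expected to move the number little, with the step of a number 1 percentage points lower from compound 2 to compound 3 (within the scatter) expected to stay within the scatter. Compound 3 is therefore expected to give about 50%, with a likely range from 30% to 70%.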

Compound 3, a percentage reported as inhibition, in the whole organism at one dose (the size of the read-out at that dose, not a potency): 30%
Compound 3: middle estimate off by 20 percentage points, on the high side, within the range that was stated.
By their numbers in this assay, from the lowest: compounds 3 and 1 (each within the scatter of the next); then compound 2.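

In this assay the change from 4-fluorophenyl to 4-methylphenyl gives a number 21 percentage points lower from compound 2 to compound 3 (beyond the scatter) and so shows that this place, on an aromatic carbon para to a large group, is sensitive to the group it carries. Within the data shown here, this is the first pair of measured compounds that differ in one place only, and the step comes from replacing one heavy atom with another, with no change in the count of hydrogen-bond donors or acceptors and no net charge on either group. No measurement shown explains the size of this step. As far as these compounds go, with only fluoro and methyl compared at this place, it remains open what a chloro group, a methoxy group or a plain hydrogen would give there. A single pair also cannot show whether the same exchange would have a similar effect on a different core.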